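Swapping an Alkenyl Arm for an Ethoxy Group

A few compounds are considered here, and "the series" means these few. Any claim that something is new, unique, unknown or untested is made for them only; others in the source may bear on it.

Among the measured compounds shown here, compound 2 `C=C(C)c1ccccc1OC(C)C1=NCCN1` has the highest number of the two compounds measured so far: in an assay on CHO cells for displacement of a labelled ligand from Alpha-2C adrenergic receptor (Homo sapiens) (a lower number here means a stronger inhibitor, a higher number a weaker inhibitor), compound 2 gives 603 nM. For the measured compounds named here, its nearest neighbour is compound 1 `CCc1ccccc1OC(C)C1=NCCN1`, which in this assay gives 288 nM; the one measured step, a 2.1-fold higher number from compound 1 to compound 2 (0.32 log units; beyond the scatter), is modest. Compound 3 `CCOc1ccccc1OC(C)C1=NCCN1` differs from compound 2 by ethoxy in place of 1-methylethenyl on an aromatic carbon. Going by the values given here, no measured step covers this exact exchange; the step from compound 1 to compound 2 altered the same aromatic carbon but brought in a different group, so it bears only loosely here, showing that a change at this carbon shifted the number modestly. A shift of similar, modest size is therefore expected, with no firm direction, so compound 3 is estimated at 400 nM, within 150 nM to 1200 nM, which means an expected step of a 1.5-fold lower number from compound 2 to compound 3 (0.18 log units; within the scatter).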

Compound 3, inhibition constant: 759 nM
Compound 3: the middle estimate sits 1.9-fold (0.28 log units) below what was measured; measured number inside the range.
By their numbers in this assay, from the lowest: compound 1; then compounds 2 and 3 (each within the scatter of the next).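

Exchanging 1-methylethenyl for ethoxy on this aromatic carbon gives a 1.3-fold higher number from compound 2 to compound 3 (0.10 log units; within the scatter) and so no real change in this assay, even though the entering group brings an oxygen and a hydrogen-bond acceptor. Measured against ethyl, ethoxy gives a 2.6-fold higher number from compound 1 to compound 3 (0.42 log units; beyond the scatter) and so joins 1-methylethenyl in raising the number beyond the scatter, which leaves ethyl with the lowest number of the three groups at this carbon. Nothing measured here explains why these groups rank this way.

From the compounds shown here alone, it remains open whether a methyl group, a chlorine atom or an amine at this carbon would bring the number below that of compound 1, or whether a longer chain would raise it further. Going by these compounds, the effect of such groups on the other aromatic carbons of the shared core also remains unknown.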